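The source may hold more compounds than are shown below. What is called first, only, known or untested is meant among the compounds shown, and "the series" means these compounds.

Measured compounds:
compound 1, `CCc1nnc2c(C#N)c(N3CCC(c4ccccc4)CC3)ccn12`, 696 nM
compound 2, `CCCc1nnc2c(C#N)c(N3CCC(c4ccccc4)CC3)ccn12`, 299 nM
compound 3, `N#Cc1c(N2CCC(c3ccccc3)CC2)ccn2c(CC(F)(F)F)cnc12`, 125 nM

The read-out is a functional assay on CHO cells for positive allosteric modulation of metabotropic glutamate receptor 2 (Homo sapiens), read by GTPgammaS binding, with a stated time of 30 min; on this read-out lower numbers stand for an effect already at smaller amounts and higher numbers for an effect only at larger amounts of compound. Compound 2 stands second highest of the three numbers: compound 1 sits above it and compound 3 below it, each separated from compound 2 by a step beyond the scatter.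

The new compound is compound 4, `N#Cc1c(N2CCC(c3ccccc3)CC2)ccn2c(CC(F)(F)F)nnc12`. It differs from compound 2 by trifluoromethyl in place of ethyl on a saturated chain carbon bound to an aromatic carbon; cut one bond further out, the chain goes from propyl to 2,2,2-trifluoroethyl.

For the measured compounds named here, only one step is a single change: a 2.3-fold lower number from compound 1 to compound 2 (0.37 log units; beyond the scatter), a change on the chain which lengthens it. Going by the values given here, no step covers a trifluoromethyl entering in place of ethyl on a chain. Among the compounds with values here, compound 3 does carry the 2,2,2-trifluoroethyl chain of compound 4, but on a different core, so its pair with compound 2 shows only that compound 3 gives 125 nM against compound 2 at 299 nM, a lower number.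

On that basis a moderate step to a lower number is expected, a 2.0-fold lower number from compound 2 to compound 4 (0.30 log units; within the scatter), though with wide uncertainty since the chain change and the core both vary against compound 3. Compound 4 is estimated at 150 nM, within 60 nM to 400 nM.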

Compound 4, half-maximal effective concentration: 56 nM
Compound 4: middle estimate off by 2.7-fold (0.43 log units), on the high side; measured number below the stated range.
By their numbers in this assay, from the lowest: compound 4; then compound 3; then compound 2; then compound 1.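

In this assay, this position on the shared core responds to more than chain length: trifluoromethyl in place of ethyl, which turns propyl into 2,2,2-trifluoroethyl, gives a 5.3-fold lower number from compound 2 to compound 4 (0.73 log units; beyond the scatter), the first step shown for a fluorinated chain at this place. Set against the shorter chain, the same position gives a 12-fold lower number from compound 1 to compound 4 (1.09 log units; beyond the scatter), the only large step in the series, and both steps lie beyond the scatter, so a fluorinated chain here is compatible with a lower number than either plain alkyl chain shown. Nothing measured on these compounds explains the change.

The compounds shown leave open whether the fluorine atoms themselves matter or whether a chain of this shape would do as well, a question that an isobutyl or a 2,2-difluoroethyl chain at the same place would address. They also leave open whether propyl and 2,2,2-trifluoroethyl would differ in the same way on the core of compound 3, which gives 125 nM and has no plain alkyl partner here.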